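The source may report more compounds than this note shows. Statements on the series, on what has been measured and on what is new or still open speak of the compounds shown alone.

Among the compounds with values here, compound 3, `O=C(Nc1ccc(-n2ncc3c(Br)cccc32)cc1)Nc1ccc(Cl)c(C(F)(F)F)c1`, is measured in a functional assay on HT-29 cells (Homo sapiens) for cytotoxicity, read by MTT assay, with a stated time of 72 h (a lower number here means a stronger inhibitor, a higher number a weaker inhibitor), and gives 4000 nM, which places it second highest of the three numbers so far. Compound 1, `O=C(Nc1ccc(-n2ncc3c(C(F)(F)F)cccc32)cc1)Nc1ccc(Cl)c(C(F)(F)F)c1`, gives 2900 nM in this assay, and compound 2, `O=C(Nc1ccc(-n2ncc3c(Cl)cccc32)cc1)Nc1ccc(Cl)c(C(F)(F)F)c1`, gives 4600 nM. The three share one core and differ only in the group on an aromatic carbon of a six-membered aromatic ring of carbon only, part of a fused system of two rings: trifluoromethyl, chloro or bromo. None of the steps among them leaves the scatter: a 1.6-fold higher number from compound 1 to compound 2 (0.20 log units; within the scatter), a 1.4-fold higher number from compound 1 to compound 3 (0.14 log units; within the scatter) and a 1.2-fold lower number from compound 2 to compound 3 (0.06 log units; within the scatter).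

Compound 4, `O=C(Nc1ccc(-n2ncc3c(F)cccc32)cc1)Nc1ccc(Cl)c(C(F)(F)F)c1`, takes the same place one step further, with fluoro in place of bromo on an aromatic carbon. The three measured exchanges at that carbon bear directly on it, and all were small, so no step beyond the scatter is expected in this assay for compound 4 in either direction. The step expected is no change at the digits printed from compound 3 to compound 4 (within the scatter). The number estimated for compound 4 is 4000 nM, with a range from 2000 nM to 8000 nM.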

Compound 4, half-maximal inhibitory concentration: 8200 nM
Compound 4: the middle estimate sits 2.1-fold (0.31 log units) below what was measured; measured number outside the range, above it.
By their numbers in this assay, from the lowest: compounds 1, 3, 2 and 4 (each within the scatter of the next, the first and the last beyond it).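

In this assay this position gives its first steps beyond the scatter, with a 2.1-fold higher number from compound 3 to compound 4 (0.31 log units; beyond the scatter) and a 2.8-fold higher number from compound 1 to compound 4 (0.45 log units; beyond the scatter) for fluoro, where the exchanges among trifluoromethyl, chloro and bromo had all stayed within it. With a 1.8-fold higher number from compound 2 to compound 4 (0.25 log units; within the scatter) the exchange from chloro stays within the scatter, so fluoro stands apart from bromo and trifluoromethyl but not from chloro. Both steps beyond the scatter are only modest, so no exchange at this carbon has yet given a large step.

On these data alone, whether an amine, a methoxy group or a nitrile on this aromatic carbon would move the number further remains open. Nothing given here accounts for the steps seen with fluoro.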